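Taking one methyl from compound 2

This account rests on a few compounds, and the source may have more. Where it says the series, first, only, none or still open, it means among the compounds named here.

Compound 1 `C=C1C=CCO[C@@H]1n1ccc(NC(=O)c2ccccc2)nc1=O` gives 296000 nM
Compound 2 `C=C1C=CCO[C@@H]1n1cc(C)c(O)nc1=O` gives 339000 nM

In a functional assay on HeLa cells (Homo sapiens), with a stated time of 3 days (a lower number here means a stronger inhibitor, a higher number a weaker inhibitor), compound 2 stands at 339000 nM and lies within the scatter of compound 1 (296000 nM). Compound 3 `C=C1C=CCO[C@@H]1n1ccc(O)nc1=O` differs from compound 2 by hydrogen in place of methyl on an aromatic carbon. Among the compounds with values here, no measured pair shows this change, so only an expectation is possible. With compound 2 at 339000 nM as the reference, no step beyond the scatter is expected in this assay (a 1.1-fold lower number from compound 2 to compound 3 (0.03 log units; within the scatter)). For compound 3 the estimated value is 320000 nM with an expected range from 130000 nM to 750000 nM (not yet measured).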

Compound 3, half-maximal inhibitory concentration: 760000 nM
Estimate against measurement, compound 3: 2.4-fold (0.38 log units) below; the whole stated range lies below it.
By their numbers in this assay, from the lowest: compounds 1 and 2 (each within the scatter of the next); then compound 3.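

Hydrogen in place of methyl on this aromatic carbon, ortho to a hydroxy group, is the first change here with a readable effect: in this assay it gives a 2.2-fold higher number from compound 2 to compound 3 (0.35 log units; beyond the scatter) and so shows that the methyl is not neutral at this position, though the step is modest. Compound 1 and compound 2 could not show this, as they differ in more than one place. Nothing available explains the step.

On these data alone, whether an ethyl group, a longer chain or a chlorine on this carbon would give a lower number than compound 2 remains open. So does whether the methyl has the same effect alongside the group that compound 1 carries.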